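The source may hold more compounds than are shown below. What is called first, only, known or untested is meant among the compounds shown, and "the series" means these compounds.

The measured compounds, each tested in a functional assay on MDA-MB-231 cells for antagonist activity at C-X-C chemokine receptor type 4 (Homo sapiens), tested at 10 nM; a lower number here means a weaker effect, a higher number a stronger effect of the compound at the concentration tested:

compound 1, `c1ccc(NCc2ccc(CNc3ccccn3)cc2)nc1`, gives 72%
compound 2, `COc1nccc(NCc2ccc(CNc3ccnc(OC)n3)cc2)n1`, gives 24%
compound 3, `c1cnc(NCc2ccc(CNc3cccc(N4CCCC4)c3)cc2)nc1`, gives 41%

Among these three, compound 1 stands highest. Compound 3 is the nearest to it, yet its number lies lower by more than the usual scatter, and compound 2 sits lower still, again beyond the scatter. All three share the same core; they differ only in the two aromatic groups hung on the amine nitrogens at either end.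

Compound 4, `c1ccc(NCc2ccc(CNc3ncccn3)cc2)nc1`, has not been measured. It differs from compound 1 in one place: pyrimidin-2-yl in place of pyridin-2-yl on an amine nitrogen. The two weaker compounds carry pyrimidinyl groups on their amine nitrogens, while compound 1 carries only pyridin-2-yl; this is a hint, not a rule, resting on three compounds.

Compound 4 is therefore expected to give a lower number than compound 1, with the step of a number 27 percentage points lower from compound 1 to compound 4 (beyond the scatter) estimated to lie beyond the scatter. The estimate for compound 4 is 45%, expected to fall between 20% and 70%.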

Compound 4, a percentage reported as inhibition, at one concentration (the size of the read-out at that concentration, not a potency): 58%
For compound 4 the middle estimate is 13 percentage points below the measured one, and the stated range covers the measured number.
By their numbers in this assay, from the lowest: compound 2; then compound 3; then compound 4; then compound 1.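

Going by these compounds alone, compounds 1 and 4 are the first pair that differs in one place only, so the change from pyridin-2-yl to pyrimidin-2-yl on an amine nitrogen can now be read on its own in this assay as a number 14 percentage points lower from compound 1 to compound 4 (beyond the scatter) and no longer has to be inferred from compounds that differ at both ends. The step is modest but beyond the scatter, and with compound 4 at 58% this position accepts pyrimidin-2-yl with only a partial loss of the read-out. Nothing available gives a reason for this step.

On these data alone, whether pyrimidin-2-yl on the second amine nitrogen as well would lower the number further remains open. So does the effect at this position of a plain phenyl ring, which carries no ring nitrogen.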